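A few compounds are considered here, and "the series" means these few. Any claim that something is new, unique, unknown or untested is made for them only; others in the source may bear on it.

Working notes on the thiosemicarbazide series. Compound 1 `CC1=CC[C@H](C(C)(C)NC(=S)NN)CC1` is the free hydrazide; in a functional assay on OVCAR-3 cells (Homo sapiens) for inhibition, read by sulforhodamine B assay, with a stated time of 48 h (a lower number here means a stronger inhibitor of growth, a higher number a weaker inhibitor of growth), compound 1 gives > 100000 nM, which is a limit of the assay and not a number. Its arylidene relatives carry numbers: compound 2 `COc1ccc(/C=N/NC(=S)NC(C)(C)[C@H]2CC=C(C)CC2)cc1` gives 21200 nM in this assay, and compound 3 `CC1=CC[C@H](C(C)(C)NC(=S)N/N=C/c2ccccc2Cl)CC1` gives 83600 nM; the step of a 3.9-fold higher number from compound 2 to compound 3 (0.60 log units; beyond the scatter) shows the aryl group matters. Compound 4 `CC1=CC[C@H](C(C)(C)NC(=S)N/N=C/c2ccco2)CC1` differs from compound 1 by a group of 7 heavy atoms (5 carbon, 1 nitrogen, 1 oxygen; one five-membered aromatic ring with 1 hetero atom) in place of one nitrogen atom, on an amide-type nitrogen. Within the data shown here, no measured step covers the arm itself, but both arylidene compounds sit below the limit of the limit of > 100000 nM in this assay, at which 1 of the 3 values shown sits, so a drop in this assay is expected. The estimate for compound 4 is 40000 nM (range 15000 nM to 100000 nM), meaning an expected step of an at least 2.5-fold lower number from compound 1 to compound 4 (0.39 log units; beyond the scatter).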

Compound 4, concentration for total growth inhibition: 13800 nM
Beside the measured number, compound 4's estimate is 2.9-fold (0.46 log units) above it; measured number outside the range, below it.
By their numbers in this assay, from the lowest: compounds 4 and 2 (each within the scatter of the next); then compound 3. At a limit, above all of these: compound 1.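

In this assay, furan-2-yl on the arm at the amide-type nitrogen gives an at least 7.2-fold lower number from compound 1 to compound 4 (0.86 log units; beyond the scatter), a size that is only a lower bound. Compound 1 remains the only compound at a limit: the limit of > 100000 nM in this assay, at which 1 of the 4 values shown sits.

On the carbon with a double bond to nitrogen, furan-2-yl gives a 6.1-fold lower number from compound 3 to compound 4 (0.78 log units; beyond the scatter) but a 1.5-fold lower number from compound 2 to compound 4 (0.19 log units; within the scatter), so a phenyl ring is not required to match compound 2, and the 2-chlorophenyl of compound 3 stands apart. Open, going by these compounds, is whether a pyridin-2-yl ring or a plain methyl group on that carbon would hold the number.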